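The compounds below may be only part of what the source reports. "The series", "measured", "known", "first", "only" and "open" are said of these compounds alone.

The measured compounds in a functional assay on MCF cells (Homo sapiens) for antiproliferative activity, with a stated time of 72 h; a higher number here means a weaker inhibitor, a lower number a stronger inhibitor:

- compound 1, `OC[C@H]1O[C@@H](n2cnc3c(NCc4cccc(F)c4)ncnc32)[C@H](O)[C@@H]1O`, gives 15300 nM
- compound 2, `OC[C@H]1O[C@@H](n2cnc3c(NCc4ccc(Cl)cc4)ncnc32)[C@H](O)[C@@H]1O`, gives > 166000 nM, which is a limit of the assay and not a number
- compound 3, `OC[C@H]1O[C@@H](n2cnc3c(NCc4ccccc4Br)ncnc32)[C@H](O)[C@@H]1O`, gives > 166000 nM, likewise a limit of the assay and not a number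

Compound 2 therefore stands at the limit of > 166000 nM in this assay, at which 2 of the 3 values shown sit. Compound 4, `Cc1cccc(CNc2ncnc3c2ncn3[C@@H]2O[C@H](CO)[C@@H](O)[C@H]2O)c1`, differs from compound 2 in one place: 3-methylphenyl in place of 4-chlorophenyl on a saturated chain carbon bound to a nitrogen on an aromatic ring. Among the compounds with values here, two measured steps bear on this change, though neither repeats it exactly: an at least 10-fold higher number from compound 1 to compound 2 (1.03 log units; beyond the scatter) and an at least 10-fold higher number from compound 1 to compound 3 (1.03 log units; beyond the scatter). The step between the two limits, a step that the two limits leave unreadable from compound 2 to compound 3, gives no readable size. Compound 4 carries a 3-methylphenyl where compound 1 carries a 3-fluorophenyl, so the reading of compound 1 is the nearest anchor, while compound 2 and compound 3 show that a single substituent on the benzyl group does not guarantee measurable inhibition. Compound 4 is expected to give a lower number than compound 2, an at least 6.6-fold lower number from compound 2 to compound 4 (0.82 log units; beyond the scatter), of uncertain size. Compound 4 is estimated at 25000 nM, between 8000 nM and 110000 nM.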

Compound 4, half-maximal inhibitory concentration: > 166000 nM
Compound 4: no number, only a limit; the forecaster's own chance of this, stated with the estimate: 25%; at least 6.6-fold (0.82 log units) between middle value and limit.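

In this assay, methyl in place of fluoro on an aromatic carbon gives an at least 10-fold higher number from compound 1 to compound 4 (1.03 log units; beyond the scatter), so the 3-methylphenyl of compound 4 does not keep the measurable reading of the 3-fluorophenyl in compound 1. Compound 1 alone of the four gives a number, and the steps among the other three cannot be read. Compound 4 sits at a limit of the assay, not a number, which it shares with compound 2 and compound 3: the limit of > 166000 nM in this assay, at which 3 of the 4 values shown sit.

The compounds shown leave open whether the reading of compound 1 belongs to fluoro alone or would also appear with a 3-chlorophenyl or a 3-methoxyphenyl in the same place. They also leave open how compound 2, compound 3 and compound 4 rank against one another, and how an unsubstituted phenyl would read.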